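This account rests on a few compounds, and the source may have more. Where it says the series, first, only, none or still open, it means among the compounds named here.

The measured compounds:
Compound 1 `CN1CCC(c2c[nH]c3ccc(NC(=O)C4CC4)nc23)CC1`: in an assay for binding affinity to 5-hydroxytryptamine receptor 1D (Homo sapiens), read by radioligand binding (a lower number here means a stronger inhibitor, a higher number a weaker inhibitor), compound 1 gives 1800 nM.
Compound 2 `Cc1cccc(C(=O)Nc2ccc3[nH]cc(C4CCN(C)CC4)c3n2)c1`: in this assay compound 2 gives 490 nM.
Compound 3 `CN1CCC(c2c[nH]c3ccc(NC(=O)c4cccs4)nc23)CC1`: in this assay compound 3 gives 650 nM.

Compound 3 stands second highest of the three numbers. Its nearest neighbour is compound 2, and the two lie within the scatter of each other: a 1.3-fold higher number from compound 2 to compound 3 (0.12 log units; within the scatter). Its furthest is compound 1: a 2.8-fold lower number from compound 1 to compound 3 (0.44 log units; beyond the scatter). Compound 4 `CN1CCC(c2c[nH]c3ccc(OS(C)(=O)=O)nc23)CC1` has not yet been measured. It differs from compound 3 by (methylsulfonyl)oxy in place of ((thiophen-2-yl)carbonyl)amino on an aromatic carbon. The measured steps all vary the group on the carbonyl carbon while the amide itself stays in place: a 3.7-fold lower number from compound 1 to compound 2 (0.57 log units; beyond the scatter) and a 2.8-fold lower number from compound 1 to compound 3 (0.44 log units; beyond the scatter). Among the compounds with values here, neither removes the amide, so no measured step bears directly on the change to compound 4. Within the data shown here, the exchange of the whole ((thiophen-2-yl)carbonyl)amino group for (methylsulfonyl)oxy has no measured counterpart here; the number in this assay for compound 4 is nevertheless expected to move higher, probably beyond the scatter, though with wide uncertainty. Compound 4 is expected to come out at 3000 nM, between 800 nM and 12000 nM. The step this implies is estimated as a 4.6-fold higher number from compound 3 to compound 4 (0.66 log units; beyond the scatter).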

Compound 4, inhibition constant: 8 nM
Compound 4: middle estimate off by 380-fold (2.57 log units), on the high side; the whole stated range lies above it.
By their numbers in this assay, from the lowest: compound 4; then compounds 2 and 3 (each within the scatter of the next); then compound 1.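

In this assay, exchanging the whole amide at this position moves the number far more than varying the group on its carbonyl carbon did: the new steps are an 81-fold lower number from compound 3 to compound 4 (1.91 log units; beyond the scatter) and a 230-fold lower number from compound 1 to compound 4 (2.35 log units; beyond the scatter), both large, whereas the change among the amides was modest at a 3.7-fold lower number from compound 1 to compound 2 (0.57 log units; beyond the scatter). The aromatic carbon next to the ring nitrogen therefore accepts (methylsulfonyl)oxy, which has no ring and no hydrogen-bond donor, and compound 4 has the lowest number of the four. Nothing available here accounts for the size of this change.

The compounds shown leave open whether the drop comes from losing the amide or from the (methylsulfonyl)oxy group itself. From the compounds shown here alone, a methoxy group, a hydroxyl group or a methanesulfonylamino group at the same carbon would help separate the two, and how any of them would read remains open.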